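The source may report more compounds than this note shows. Statements on the series, on what has been measured and on what is new or still open speak of the compounds shown alone.

Of the compounds shown here, two built on the same core have been measured so far. Compound 1 `CCc1cccc(NC(=O)CN2CCC(c3cccc[n+]3[O-])CC2)c1` in a functional assay on HEK293 cells for agonist activity at D(4) dopamine receptor (Homo sapiens), read by FLIPR (on this read-out higher numbers stand for an effect only at larger amounts of compound and lower numbers for an effect already at smaller amounts), gives 95 nM. Compound 2 `Cc1cc(C(=O)NCN2CCC(c3cccc[n+]3[O-])CC2)ccc1F` in this assay gives 50 nM. These two numbers lie within the usual scatter of each other, so compound 2 stands at the lower of the two numbers without being separated from compound 1 by more than repeated measurements of the same compound would produce.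

Compound 3 `O=C(NCN1CCC(c2cccc[n+]2[O-])CC1)c1ccccc1` has not yet been measured. It differs from compound 2 in one place: phenyl in place of 4-fluoro-3-methylphenyl on a carbonyl carbon. The ring attached to the carbonyl carbon thus loses its fluorine and its methyl and becomes a bare phenyl. Among the compounds with values here, no measured pair shows what such a change does here, so the expected size of the step rests on the change itself and on the narrow spread of the two numbers already seen. A modest weakening is expected, of a size that may just exceed the scatter; the expected step is a 2.2-fold higher number from compound 2 to compound 3 (0.34 log units; beyond the scatter). Compound 3 is therefore estimated at 110 nM, with a range from 35 nM to 350 nM.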

Compound 3, half-maximal effective concentration: 532 nM
The estimate for compound 3 lay 4.8-fold (0.68 log units) below the measured number, outside the stated range (above it).
By their numbers in this assay, from the lowest: compounds 2 and 1 (each within the scatter of the next); then compound 3.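

In this assay the ring on the carbonyl carbon matters far more than the first two numbers could show: going from 4-fluoro-3-methylphenyl to bare phenyl brings an 11-fold higher number from compound 2 to compound 3 (1.03 log units; beyond the scatter) and so marks a large step, meaning that much more of compound 3 is needed for the same effect. Within the data shown here, this is the first pair here that differs in one place only, and it shows that the loss of a fluorine and a methyl from the ring, with the rest of the molecule unchanged, is enough to move the number well beyond the scatter. No measurement at hand gives a reason for the size of this step.

The compounds shown cannot say whether the fluorine, the methyl or the two together account for the step, since both leave at once and a phenyl carrying only the fluorine or only the methyl would be needed to separate them. As far as these compounds go, it also remains open whether other groups on this ring, such as a chlorine or a methoxy group, would give a number nearer that of compound 2 or that of compound 3.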